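This account rests on a few compounds, and the source may have more. Where it says the series, first, only, none or still open, it means among the compounds named here.

Working notes on the series. The shared core is that of compound 1 `CSc1nc2c([nH]1)C(=O)C=CC2=O`, which in a functional assay on SUP-T1 cells (Homo sapiens) for antiproliferative activity (a higher number here means a weaker inhibitor, a lower number a stronger inhibitor), gives 2.87 uM. Compound 3 `CSc1nc2c([nH]1)C(=O)C(Br)=C(Br)C2=O` gives 6.26 uM in this assay. Compound 2 `CSc1nc2c([nH]1)C(=O)C=C(N(C)C)C2=O` gives 38 uM and so stands highest of the three numbers, beyond the scatter from both compound 3 and compound 1. Among the compounds with values here, the one step that leads to compound 2 is a 13-fold higher number from compound 1 to compound 2 (1.12 log units; beyond the scatter): the dimethylamino on the double-bonded ring carbon goes with a markedly higher number.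

Compound 4 `COC1=CC(=O)c2[nH]c(SC)nc2C1=O` is not yet measured. It differs from compound 2 by methoxy in place of dimethylamino on a double-bonded ring carbon. Within the data shown here, no measured step shows a methoxy at this place, so the bearing of the known steps is indirect: the large rise in a 13-fold higher number from compound 1 to compound 2 (1.12 log units; beyond the scatter) shows that this ring carbon tolerates the dimethylamino poorly, and a smaller acceptor group there is expected to give a number somewhere between compound 2 and the unsubstituted compound 1. The expected step is therefore a moderate fall, a 3.8-fold lower number from compound 2 to compound 4 (0.58 log units; beyond the scatter). Compound 4 is estimated at 10 uM in this assay, within a range of 3 uM to 35 uM.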

Compound 4, concentration for 50% inhibition: 5.07 uM
Compound 4: middle estimate off by 2.0-fold (0.29 log units), on the high side, within the range that was stated.
By their numbers in this assay, from the lowest: compounds 1, 4 and 3 (each within the scatter of the next, the first and the last beyond it); then compound 2.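

In this assay, the double-bonded ring carbon can carry a substituent without a step beyond the scatter: a 1.8-fold higher number from compound 1 to compound 4 (0.25 log units; within the scatter) is seen with methoxy in place of hydrogen, while a 7.5-fold lower number from compound 2 to compound 4 (0.87 log units; beyond the scatter) is seen with methoxy in place of dimethylamino. The large rise seen with compound 2 therefore does not apply to every replacement of hydrogen at this place, and among the groups shown here it goes only with dimethylamino. Nothing at hand accounts for the difference between methoxy and dimethylamino on this carbon.

As far as these compounds go, whether a primary amine or a morpholine on this ring carbon would read like dimethylamino or like methoxy remains open. From the compounds shown here alone, it is equally open whether an ethoxy group or a longer alkoxy chain would stay level with methoxy.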